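From Ethyl Ester to Primary Amide at the Assay Limit

The compounds below may be only part of what the source reports. "The series", "measured", "known", "first", "only" and "open" are said of these compounds alone.

Measured so far:
compound 1, `CCOC(=O)c1sc2ccccc2c1N`, in an assay on isolated protein for inhibition of LIM domain kinase 1 (Homo sapiens), read by Kinase-Glo, with a stated time of 60 min (a higher number here means a weaker inhibitor, a lower number a stronger inhibitor), gives > 100000 nM
compound 2, `CNC(=O)c1sc2ncccc2c1N`, in this assay gives > 100000 nM

The value of compound 1 is a limit of the assay, not a number. The value of compound 2 is likewise a limit. Every value shown rests on (the limit of > 100000 nM in this assay, at which 2 of the 2 values shown sit), so compound 1 stands at the weak end of what can be told. Compound 3, `NC(=O)c1sc2ccccc2c1N`, differs from compound 1 by amino in place of ethoxy on a carbonyl carbon. Among the compounds with values here, no measured pair shows this change. The step is expected to be a number no higher from compound 1 to compound 3 (the limit leaves the size open), with no direction beyond the scatter. In this assay compound 3 is expected to give 100000 nM, between 20000 nM and 300000 nM.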

Compound 3, half-maximal inhibitory concentration: 33000 nM
Beside the measured number, compound 3's estimate is 3.0-fold (0.48 log units) above it; measured number inside the range.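

Amino in place of ethoxy on a carbonyl carbon brings an at least 3.0-fold lower number from compound 1 to compound 3 (0.48 log units; beyond the scatter) in this assay. Within the data shown here, compound 3 is the first compound here to give a number rather than a limit, so a change at this one place can bring inhibition into the range the assay can read. The full size of the step stays unknown because its starting point is a limit: the limit of > 100000 nM in this assay, at which 2 of the 3 values shown sit.

On these data alone, whether a carboxylic acid or a longer amine on the carbonyl carbon would lower the number further remains open. A single pair also cannot show whether this change would act the same way on another core.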